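Methyl added to the chlorophenyl urea of compound 1

The compounds below may be only part of what the source reports. "The series", "measured", "known", "first", "only" and "open" are said of these compounds alone.

Measured so far in a functional assay on A549 cells (Homo sapiens) for inhibition, with a stated time of 72 h; a lower number here means a stronger inhibitor, a higher number a weaker inhibitor:
compound 1 `O=C(Nc1ccc(Cl)cc1)Nc1nc(Sc2c[nH]c3ccccc23)cc(N2CCCC2)n1` gives 6410 nM
compound 2 `O=C(Nc1ccc(Cl)cc1)Nc1nc(Sc2c[nH]c3ccccc23)cc(N2CCCCC2)n1` gives 18600 nM

Compound 1 holds the lowest of the two numbers. Among the measured compounds shown here, the only measured step, a 2.9-fold higher number from compound 1 to compound 2 (0.46 log units; beyond the scatter), concerns piperidin-1-yl in place of pyrrolidin-1-yl on an aromatic carbon, a modest change on the other side of the shared core.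

Compound 3 `Cc1cc(Cl)ccc1NC(=O)Nc1nc(Sc2c[nH]c3ccccc23)cc(N2CCCC2)n1` differs from compound 1 by methyl in place of hydrogen on an aromatic carbon. For the measured compounds named here, no measured step touches this part of the molecule, so nothing argues for a shift beyond the scatter in this assay. For compound 3 the estimated step is a 1.1-fold lower number from compound 1 to compound 3 (0.03 log units; within the scatter). Compound 3 is expected at 6000 nM, between 2500 nM and 15000 nM.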

Compound 3, half-maximal inhibitory concentration: 8930 nM
For compound 3 the middle estimate is 1.5-fold (0.17 log units) below the measured one, within the range that was stated.
By their numbers in this assay, from the lowest: compounds 1 and 3 (each within the scatter of the next); then compound 2.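

In this assay, among the compounds shown here, the change from 4-chlorophenyl to 4-chloro-2-methylphenyl (a 1.4-fold higher number from compound 1 to compound 3 (0.14 log units; within the scatter)) gives the first reading on this side of the shared core, and methyl on this aromatic carbon, ortho to a large group, does not separate the two compounds. For the compounds shown here, the only earlier step concerned the other side of the core. No available data bear on this result.

On these data alone, a methoxy group, an amine or a carboxylic acid on this carbon remains open. So does replacement of the chloro group by fluoro or bromo.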